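Swapping a cyclohexyl tail for a butylphenyl tail

A few compounds are considered here, and "the series" means these few. Any claim that something is new, unique, unknown or untested is made for them only; others in the source may bear on it.

The measured compounds:
compound 1, `CCCCCCCCCCCCCCc1ccccc1C(SCCC(=O)O)SCCC(=O)O`, gives 1250 nM in an assay on membranes from lung (Cavia porcellus) for binding affinity to cysteinyl leukotriene receptor (Homo sapiens); on this read-out higher numbers stand for weaker inhibition and lower numbers for stronger inhibition;
compound 2, `O=C(O)CCSC(SCCC(=O)O)c1ccccc1CCCCCCCCC1CCCCC1`, gives 1960 nM in this assay.

Compound 2 stands highest of the two numbers in this assay, with compound 1 as its nearest neighbour; the step of a 1.6-fold higher number from compound 1 to compound 2 (0.20 log units; within the scatter). The unmeasured compound 3, `CCCCc1ccc(CCCCc2ccccc2C(SCCC(=O)O)SCCC(=O)O)cc1`, differs from compound 2 by 4-butylphenyl in place of 4-cyclohexylbutyl on a saturated chain carbon, four bonds along the chain from an aromatic carbon. Going by the values given here, only one measured step bears on this change: the step of a 1.6-fold higher number from compound 1 to compound 2 (0.20 log units; within the scatter), in which a saturated ring replaced the open end of the long chain without moving the number beyond the scatter. The change to compound 3 is of a different kind, since a saturated ring gives way to an aromatic one and the chain between the two rings is cut shorter, so the measured step covers it only loosely. With nothing in the two measured compounds pointing to a sizeable move in either direction, compound 3 is expected to give a number close to that of compound 2, and the step of a 1.3-fold lower number from compound 2 to compound 3 (0.12 log units; within the scatter) is expected to stay within the scatter. The estimate for compound 3 in this assay is 1500 nM, between 500 nM and 4500 nM.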

Compound 3, inhibition constant: 4230 nM
Beside the measured number, compound 3's estimate is 2.8-fold (0.45 log units) below it, within the range that was stated.
By their numbers in this assay, from the lowest: compounds 1 and 2 (each within the scatter of the next); then compound 3.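

In this assay, a change on a saturated chain carbon, four bonds along the chain from an aromatic carbon, now moves the number beyond the scatter: 4-butylphenyl in place of 4-cyclohexylbutyl, with the same heavy atom count and carbon only in both groups, gives a 2.2-fold higher number from compound 2 to compound 3 (0.33 log units; beyond the scatter) and so points to weaker inhibition. Against the open chain the same group gives a 3.4-fold higher number from compound 1 to compound 3 (0.53 log units; beyond the scatter) in the same direction, which sets compound 3 apart from both earlier compounds, although the earlier step from hexyl to cyclohexyl stayed within the scatter, so this position does respond to the choice of tail, if only modestly. Nothing measured here accounts for the rise.

Compound 3 differs from compound 2 both in the aromatic ring and in where that ring sits along the tail, and these two changes remain unseparated. Also open, from the compounds shown here alone, is how the number would respond to a 4-butylphenyl group on a longer chain, or to a tail ending in an amine or a carboxylic acid.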